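The source may hold more compounds than are shown below. What is called first, only, known or untested is meant among the compounds shown, and "the series" means these compounds.

In a functional assay on HT-29 cells (Homo sapiens) for cytotoxicity, read by MTT assay, with a stated time of 24 h (a higher number here means a weaker inhibitor, a lower number a stronger inhibitor), compound 2 `Cc1ncc([N+](=O)[O-])n1CCn1ccnc1` gives 115 ug/mL. Among the measured compounds shown here, that is the smaller of the two numbers measured so far, yet compound 1 `Cc1ncc([N+](=O)[O-])n1CCOc1ccccc1` gives 134 ug/mL in this assay, and the gap between them is within the scatter, so the two cannot be told apart. Compound 3 `Cc1nccn1CCn1c([N+](=O)[O-])cnc1C` differs from compound 2 by methyl in place of hydrogen on an aromatic carbon. For the measured compounds named here, no step between two measured compounds is available to guide this change, and such a small addition is expected to move the number little, if at all, beyond the scatter. Compound 3 is therefore estimated at 110 ug/mL, within a range of 60 ug/mL to 200 ug/mL, an expected step of a 1.0-fold lower number from compound 2 to compound 3 (0.02 log units; within the scatter).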

Compound 3, half-maximal inhibitory concentration: 142 ug/mL
Compound 3: the middle estimate sits 1.3-fold (0.11 log units) below what was measured, and the stated range covers the measured number.
By their numbers in this assay, from the lowest: compounds 2, 1 and 3 (each within the scatter of the next).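

Placing methyl on this aromatic carbon, between two ring nitrogen atoms, gives the first direct step at this position: in this assay the change is a 1.2-fold higher number from compound 2 to compound 3 (0.09 log units; within the scatter) and so cannot be told apart from no change at all. This site, next to the ring atom that bears a large group, therefore takes one added carbon without a readable shift in the number. Nothing measured here offers an explanation for this result.

On these data alone, whether an amine or a longer chain on the same carbon would move the number beyond the scatter stays open. So does whether methyl would behave the same way on a different core.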